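A Single Added Side Chain on a Weak Compound

A few compounds are considered here, and "the series" means these few. Any claim that something is new, unique, unknown or untested is made for them only; others in the source may bear on it.

compound 1 `Cc1ccc(/C=C/C(=O)Oc2ccc(/C=C3\CCCCC3=O)cc2)cc1` gives 230000 nM
compound 2 `O=C(/C=C/c1ccc(F)cc1)Oc1ccc(/C=C2\CCCCC2=O)cc1` gives 14400 nM
compound 3 `O=C(/C=C/c1ccc(Br)cc1)Oc1ccc(/C=C2\CCCCC2=O)cc1` gives 131000 nM

These values come from a functional assay on CCRF-CEM cells (Homo sapiens); a higher number here means a weaker inhibitor, a lower number a stronger inhibitor. Compound 1 stands at the weak end of this small set, alongside compound 3, as a 1.8-fold lower number from compound 1 to compound 3 (0.24 log units; within the scatter) shows. Compound 2 is clearly stronger, with a 16-fold lower number from compound 1 to compound 2 (1.20 log units; beyond the scatter) and a 9.1-fold higher number from compound 2 to compound 3 (0.96 log units; beyond the scatter).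

Compound 4 `Cc1ccc(/C=C/C(=O)Oc2ccc(/C=C3\CCCC(CN(C)C)C3=O)cc2)cc1` differs from compound 1 by one change: (dimethylamino)methyl in place of hydrogen on a saturated ring carbon. Within the data shown here, no measured step touches that place, since all three swap groups on an aromatic carbon. They therefore offer only a rough guide to size. The clearest guide is a 16-fold lower number from compound 1 to compound 2 (1.20 log units; beyond the scatter), which shows that one small change can move a weak compound a long way in this set. With compound 1 at 230000 nM, there is far more measured room below it than above it. A lower number in this assay is therefore expected, by a large step, though this remains uncertain. The expected value for compound 4 is 12000 nM, within an estimated range from 1500 nM to 90000 nM. The expected change is a 19-fold lower number from compound 1 to compound 4 (1.28 log units; beyond the scatter).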

Compound 4, half-maximal inhibitory concentration: 7020 nM
The estimate for compound 4 lay 1.7-fold (0.23 log units) above the measured number, and the stated range covers the measured number.
By their numbers in this assay, from the lowest: compound 4; then compound 2; then compounds 3 and 1 (each within the scatter of the next).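

In this assay, the only change shown on a saturated ring carbon gives a 33-fold lower number from compound 1 to compound 4 (1.52 log units; beyond the scatter), a large step. The earlier compounds shown here showed movement only from swaps on an aromatic carbon, whereas this result shows that the six-membered non-aromatic ring is also a place where one added group can strongly change the number. Nothing measured here explains why the (dimethylamino)methyl group has this effect.

The compounds shown do not reveal whether the nitrogen matters or whether almost any added group would do, and a plain methyl, a longer chain or a carboxylic acid on the same carbon would help separate those cases. Going by these compounds, it also remains open whether this side chain would lower the number in the same way on compound 2, which carries fluoro on the aromatic carbon.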